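Closing an open amide into a ring on a shared core

The source may report more compounds than this note shows. Statements on the series, on what has been measured and on what is new or still open speak of the compounds shown alone.

Measured compounds:
compound 1 `CON(C)C(=O)c1ccc(-c2ccc(OCC3CCN(C(=O)OC(C)(C)C)CC3)cn2)cc1`: 171 nM
compound 2 `CC(C)(C)OC(=O)N1CCC(COc2ccc(-c3ccc(C(=O)NOCc4ccccc4)cc3)nc2)CC1`: "not determined" (no result reported)

In a functional assay on cells for agonist activity at Glucose-dependent insulinotropic receptor (Homo sapiens), read by a luciferase reporter, with a stated time of 6 h (on this read-out higher numbers stand for an effect only at larger amounts of compound and lower numbers for an effect already at smaller amounts), compound 1 gives 171 nM. For compound 2 no single number stands in this assay; its result is "not determined" (no result reported). Compound 3 `CC(C)(C)OC(=O)N1CCC(COc2ccc(-c3ccc(C(=O)N4CCCCO4)cc3)nc2)CC1` differs from compound 2 at one place: a group of 6 heavy atoms (4 carbon, 1 nitrogen, 1 oxygen; one six-membered non-aromatic ring with 2 hetero atoms) in place of a group of 9 heavy atoms (7 carbon, 1 nitrogen, 1 oxygen; one six-membered aromatic ring of carbon only), on a carbonyl carbon. Among the measured compounds shown here, with no measured step on this carbonyl, only a weak expectation is possible. The change is expected to shift activity in this assay little, not beyond the scatter, in either direction. Compound 3 is estimated at 150 nM, with a range from 40 nM to 600 nM.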

Compound 3, half-maximal effective concentration: 321 nM
Compound 3: the middle estimate sits 2.1-fold (0.33 log units) below what was measured; the range from low to high includes it.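

Putting the six-membered non-aromatic ring with 2 hetero atoms on the carbonyl carbon in place of the open group without a ring gives a 1.9-fold higher number from compound 1 to compound 3 (0.27 log units; within the scatter) in this assay. This first measured step on the carbonyl shows that closing the open amide into this ring leaves activity within the usual scatter. Nothing measured here bears on the reason for this result. Steps involving compound 2 cannot be read, since it has no number. From the compounds shown here alone, how a carboxylic acid or a morpholine ring on this carbonyl carbon would read stays open.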